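The compounds below may be only part of what the source reports. "The series", "measured", "known", "first", "only" and "open" are said of these compounds alone.

Working notes on the amide series. Within the data shown here, compound 1 `Cc1nc(C(F)(F)F)ccc1C(=O)Nc1ccc(Cl)c(-c2nc3c(n2C)CCCC3)c1` is the reference point: in an assay on C3H 10T1/2 cells for inhibition of Sonic hedgehog protein (Mus musculus), read by a luciferase reporter (on this read-out higher numbers stand for weaker inhibition and lower numbers for stronger inhibition), compound 1 gives 150 nM, the lowest of the two numbers measured so far. Compound 2 `Cc1nc(C(F)(F)F)ccc1C(=O)Nc1ccc(Cl)c(-c2cnccn2)c1` carries a smaller ring at the same position, and in this assay compound 2 gives 1700 nM; the step of an 11-fold higher number from compound 1 to compound 2 (1.05 log units; beyond the scatter) shows that replacing the group of compound 1 with the smaller six-membered aromatic ring with 2 hetero atoms costs a great deal.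

Compound 3 `Cc1nc(C(F)(F)F)ccc1C(=O)Nc1ccc(Cl)c(-c2cnc3ccccc3n2)c1` is not yet measured. Relative to compound 1 the change is a group of 10 heavy atoms (8 carbon, 2 nitrogen; one six-membered aromatic ring of carbon only, one six-membered aromatic ring with 2 hetero atoms) in place of a group of 10 heavy atoms (8 carbon, 2 nitrogen; one five-membered aromatic ring with 2 hetero atoms, one six-membered non-aromatic ring of carbon only), on an aromatic carbon. Among the measured compounds shown here, the only measured step that bears on it is the one from compound 1 to compound 2, which was large. Compound 3 keeps the heavy-atom count of compound 1 but changes the ring type toward that of compound 2, so a step in this assay is expected somewhere between no change and the loss seen with compound 2, most likely a moderate rise in the number; the expected step is a 2.7-fold higher number from compound 1 to compound 3 (0.43 log units; beyond the scatter). Compound 3 is therefore estimated at 400 nM, with a range from 120 nM to 1500 nM.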

Compound 3, half-maximal inhibitory concentration: 52 nM
Compound 3: the middle estimate sits 7.7-fold (0.89 log units) above what was measured, outside the stated range (below it).
By their numbers in this assay, from the lowest: compound 3; then compound 1; then compound 2.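

In this assay, quinoxalin-2-yl in place of pyrazin-2-yl gives a 33-fold lower number from compound 2 to compound 3 (1.51 log units; beyond the scatter), so the extra six-membered aromatic ring of carbon only carries a large part of the result at this position, and the weak result of compound 2 does not extend to every six-membered aromatic ring with 2 hetero atoms. Against the group of compound 1, which has the same counts of heavy atoms, carbon, nitrogen, donors and acceptors, quinoxalin-2-yl gives a 2.9-fold lower number from compound 1 to compound 3 (0.46 log units; beyond the scatter), so those counts alone do not set the number here and a fully aromatic pair of rings is compatible with the lowest number in the series so far. Nothing measured on these compounds explains either step.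

Still open, going by these compounds, is how much depends on the ring nitrogens of quinoxalin-2-yl, a question that naphthalen-2-yl or quinolin-2-yl at the same place would address. Also open, on these data alone, is whether the advantage of quinoxalin-2-yl over the group of compound 1 would persist with a methyl group or a methoxy group in place of the chloro group.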